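Halogen swap on the aryl ring: compound 1 to compound 4

This account rests on a few compounds, and the source may have more. Where it says the series, first, only, none or still open, it means among the compounds named here.

Measured compounds:
compound 1 `COc1ccc2sc(C(=O)NC(=O)c3ccc(F)cc3OC)cc2c1`, 47.1%
compound 2 `COc1ccc2sc(C(=O)NC(=O)c3cc(F)ccc3OC)cc2c1`, 52.6%
compound 3 `COc1ccc2sc(C(=O)NC(=O)c3cc(Cl)ccc3OC)cc2c1`, 19.9%

In an assay for inhibition of dual specificity protein kinase CLK2 (Homo sapiens), with a stated time of 15 min, tested at 0.25 uM, in the presence of a further agent that is not named here (a higher number here means more inhibition at the concentration tested (going by the name of the read-out), a lower number less inhibition), compound 1 gives 47.1%, the second highest of the three numbers. Compound 2 gives 52.6%, which lies within the scatter of compound 1. Compound 3 gives 19.9%, beyond the scatter below compound 1.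

Compound 4 `COc1ccc2sc(C(=O)NC(=O)c3ccc(Br)cc3OC)cc2c1` has not been measured. It differs from compound 1 in one place: bromo in place of fluoro on an aromatic carbon. For the measured compounds named here, the only measured step that bears on this change is a number 32.7 percentage points lower from compound 2 to compound 3 (beyond the scatter), a chloro in place of fluoro on the same ring, though at another place on that ring. Going by the values given here, no fluoro-to-bromo step has been measured. Given that single large drop, a drop is expected for compound 4 as well, and the estimated step is a number 27.1 percentage points lower from compound 1 to compound 4 (beyond the scatter). Compound 4 is therefore estimated at 20%, with a range from 5% to 40%.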

Compound 4, a percentage reported as inhibition, at one concentration (the size of the read-out at that concentration, not a potency): 3.4%
Estimate against measurement, compound 4: 16.6 percentage points above; measured number below the stated range.
By their numbers in this assay, from the lowest: compound 4; then compound 3; then compounds 1 and 2 (each within the scatter of the next).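

Halogen at the position para to a large group: in this assay, bromo in place of fluoro gives a number 43.7 percentage points lower from compound 1 to compound 4 (beyond the scatter), so this position does not accept the swap without a large loss. For the compounds shown here, the only earlier halogen step, a number 32.7 percentage points lower from compound 2 to compound 3 (beyond the scatter), was chloro in place of fluoro at another place on the ring, so a large fall now appears at a second place and with a second halogen. No measurement on hand accounts for this fall.

Still open, as far as these compounds go, is whether the loss follows the halogen or the place, which would take chloro at this position and bromo at the other one. Also open, from the compounds shown here alone, is how a non-halogen group, such as an amine or a carboxylic acid, would read at this position.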